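Series notes: compound 3 to compound 4 in this assay

A few compounds are considered here, and "the series" means these few. Any claim that something is new, unique, unknown or untested is made for them only; others in the source may bear on it.

Four compounds share one core. Compound 1 `O=c1c2cnn(-c3ccc(F)cc3)c2ncn1CC1(O)CCN(Cc2ccccc2)CC1` in an assay on Sf21 cells for inhibition of ubiquitin carboxyl-terminal hydrolase 7 (Homo sapiens), read by spectrophotometry, with stated times of 30 min and 2 h (a lower number here means a stronger inhibitor, a higher number a weaker inhibitor), gives "not determined" (no result reported), and compound 2 `O=c1c2cnn(-c3ccc(F)cc3)c2ncn1CC1(O)CCN(Cc2ccc(F)cc2)CC1` in this assay gives "not determined" (no result reported); no number was reported for either. Going by the values given here, compound 3 `O=c1c2cnn(-c3ccc(F)cc3)c2ncn1CC1(O)CCN(Cc2ccccc2Cl)CC1` is the only entry with a number: in this assay compound 3 gives 3400 nM. With nothing else measured, compound 3 stands alone and no ordering within the series can be drawn.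

Compound 4 `N#Cc1cc(Cl)ccc1CN1CCC(O)(Cn2cnc3c(cnn3-c3ccc(F)cc3)c2=O)CC1` is the next entry, still to be measured. Its difference from compound 3 is 4-chloro-2-cyanophenyl in place of 2-chlorophenyl on a saturated chain carbon bound to an amine nitrogen in a ring. Among the compounds with values here, no step between measured compounds exists to calibrate this change, so the expectation rests on the single value of compound 3 and on the size of the change, which is a modest extension of the same group.

For compound 4, the step from compound 3 is expected to be small, a 1.4-fold lower number from compound 3 to compound 4 (0.13 log units; within the scatter), at or barely beyond the usual scatter, with a slight lean toward a stronger result. Compound 4 is therefore estimated at 2500 nM, within a range of 800 nM to 8000 nM.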

Compound 4, half-maximal inhibitory concentration: 11400 nM
Beside the measured number, compound 4's estimate is 4.6-fold (0.66 log units) below it; measured number above the stated range.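

In this assay the series gains its first readable step, with a 3.4-fold higher number from compound 3 to compound 4 (0.53 log units; beyond the scatter) for 4-chloro-2-cyanophenyl in place of 2-chlorophenyl. This step lies beyond the scatter and runs towards a weaker inhibitor, so the position on a saturated chain carbon bound to an amine nitrogen in a ring does respond to what the aromatic ring carries. The entering group, with more heavy atoms and a hydrogen-bond acceptor, brought no gain over compound 3.

Steps involving compound 1 and compound 2 cannot be read, and this single pair does not separate the nitrile from the different chlorine placement. Whether a methoxy group or an amine in place of the nitrile would read differently stays open, and no measurement shown bears on the cause of this step.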